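The compounds below may be only part of what the source reports. "The series", "measured", "known", "first", "only" and "open" are said of these compounds alone.

Of the compounds shown here, three sharing one core have been tested in a functional assay on NCI-H460 cells (Homo sapiens) for cytotoxicity, read by MTT assay, with a stated time of 72 h; a higher number here means a weaker inhibitor, a lower number a stronger inhibitor. Compound 1 `CN(C)CCNc1nc(-c2ccc(NC(=O)Nc3ccccc3)cc2)nc2ccsc12` gives 640 nM. Compound 2 `CN(C)CCNc1nc(-c2ccc(NC(=O)Nc3ccccc3F)cc2)nc2ccsc12` gives 410 nM. Compound 3 `CN(C)CCNc1nc(-c2ccc(NC(=O)Nc3ccc(Cl)cc3Cl)cc2)nc2ccsc12` gives 1650 nM, the highest of the three numbers. Its nearest neighbour is compound 1, the step of a 2.6-fold higher number from compound 1 to compound 3 (0.41 log units; beyond the scatter), and the step of a 4.0-fold higher number from compound 2 to compound 3 (0.60 log units; beyond the scatter) is larger still; both come from exchanging the group on the amide-type nitrogen. The step of a 1.6-fold lower number from compound 1 to compound 2 (0.19 log units; within the scatter), also at that nitrogen, stays within the scatter.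

Compound 4 `CCN(CC)CCNc1nc(-c2ccc(NC(=O)Nc3ccc(Cl)cc3Cl)cc2)nc2ccsc12` has not yet been measured. It differs from compound 3 in one place: diethylamino in place of dimethylamino on a saturated chain carbon, two bonds along the chain from a nitrogen on an aromatic ring. Among the compounds with values here, none of the measured steps touch this part of the molecule; all three concern the group on the amide-type nitrogen, so no measured step speaks directly to what this change does. With nothing pointing either way, the expectation is a step no larger than the scatter in this assay, in either direction, and the range is kept wide to reflect that. The estimate for compound 4 is therefore 1500 nM, between 550 nM and 4500 nM. The expected step is a 1.1-fold lower number from compound 3 to compound 4 (0.04 log units; within the scatter), which means no real change.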

Compound 4, half-maximal inhibitory concentration: 1890 nM
Compound 4: the middle estimate sits 1.3-fold (0.10 log units) below what was measured; the range from low to high includes it.
By their numbers in this assay, from the lowest: compounds 2 and 1 (each within the scatter of the next); then compounds 3 and 4 (each within the scatter of the next).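

Within the data shown here, the swap of dimethylamino for diethylamino on the saturated chain gives a 1.1-fold higher number from compound 3 to compound 4 (0.06 log units; within the scatter) in this assay, which is the first measured reading at this end of the molecule, as every earlier step concerned the group on the amide-type nitrogen. The two compounds stand within the scatter of each other, so at this position, with the 2,4-dichlorophenyl group in place, a larger amine of 5 heavy atoms instead of 3 gives a number that cannot be told apart from the original. No independent measurement bears on this result, so it stands as an observation without an explanation.

What the compounds shown leave open is whether the same swap would give the same result alongside the phenyl group of compound 1 or the 2-fluorophenyl group of compound 2, since this single step comes from one background only. They also leave open how far this end of the molecule can be altered, for example with dipropylamino, with a primary amine, with a hydroxyl group in place of the amine, or with a longer chain leading to the amine.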